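Halogen swap on the des-methyl acylguanidine core

The source may hold more compounds than are shown below. What is called first, only, known or untested is meant among the compounds shown, and "the series" means these compounds.

Measured so far in a functional assay for inhibition of sodium/hydrogen exchanger (Oryctolagus cuniculus); on this read-out higher numbers stand for weaker inhibition and lower numbers for stronger inhibition:
compound 1 `Cc1cc(Cl)c(S(C)(=O)=O)cc1C(=O)N=C(N)N`, 25 nM
compound 2 `Cc1cc(Br)c(S(C)(=O)=O)cc1C(=O)N=C(N)N`, 12 nM
compound 3 `CS(=O)(=O)c1cc(C(=O)N=C(N)N)ccc1Cl`, 380 nM

Compound 3 stands highest of the three numbers. Its core differs from that of compound 1 by hydrogen in place of methyl on an aromatic carbon, and that change gave a 15-fold higher number from compound 1 to compound 3 (1.18 log units; beyond the scatter).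

Compound 4 `CS(=O)(=O)c1cc(C(=O)N=C(N)N)ccc1Br` has not yet been measured. It differs from compound 3 by bromo in place of chloro on an aromatic carbon. The same kind of change separates compound 1 from compound 2, namely (bromo in place of chloro on an aromatic carbon), and in two pairs in all. The surroundings of the place are not identical: in compound 1 the place is also meta to a methyl group, whereas in compound 3 it is not. In the measured pair the change gave a 2.1-fold lower number from compound 1 to compound 2 (0.32 log units; beyond the scatter).

For compound 4 a step of a 2.1-fold lower number from compound 3 to compound 4 (0.32 log units; beyond the scatter) is expected, because the same kind of change gave a 2.1-fold lower number from compound 1 to compound 2 (0.32 log units; beyond the scatter). Whether the missing methyl group alters the outcome of the halogen swap is not shown by any pair here. Compound 4 is expected to give about 180 nM, with a likely range from 80 nM to 450 nM.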

Compound 4, half-maximal inhibitory concentration: 180 nM
The estimate for compound 4 equals the measured number at the digits printed; measured number inside the range.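

In this assay, the halogen swap carries over from the core of compound 1 to the core lacking the methyl group, with a 2.1-fold lower number from compound 3 to compound 4 (0.32 log units; beyond the scatter), and the two steps agree: the same change on two cores in this assay, a 2.1-fold lower number (0.32 log units; beyond the scatter) from compound 1 to compound 2 and a 2.1-fold lower number (0.32 log units; beyond the scatter) from compound 3 to compound 4, 1.0-fold (0.01 log units) apart, within the scatter of two such steps

Read the other way round the same square, removing the methyl group gives a 15-fold higher number from compound 2 to compound 4 (1.18 log units; beyond the scatter), which matches the step seen with chloro: the same change on two cores in this assay, a 15-fold higher number (1.18 log units; beyond the scatter) from compound 1 to compound 3 and a 15-fold higher number (1.18 log units; beyond the scatter) from compound 2 to compound 4, 1.0-fold (0.01 log units) apart, within the scatter of two such steps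

The two changes therefore behave independently across these four compounds, so in this small set the effect of either change can be carried from one core to the other, but two pairs per change show neither why this is so nor that it extends to any other group or core.

The compounds shown leave open whether the same steps hold for fluoro, iodo or an amine in place of the halogen, or for ethyl or methoxy in place of the methyl group. As far as these compounds go, the methylsulfonyl group is common to all four compounds, so how an ethylsulfonyl group or a sulfonamide there would affect either step also stays open.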